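Dropping the trifluoromethyl: what to expect of compound 4

The source may hold more compounds than are shown below. What is called first, only, known or untested is meant among the compounds shown, and "the series" means these compounds.

Measured so far:
compound 1 `COc1cc(/C=N/Nc2nc(-c3cccc(Br)c3)cs2)cc(Br)c1OC` 66200 nM
compound 2 `COc1cc(/C=N/Nc2nc(-c3ccccc3)cs2)c(Br)c(Br)c1OC` 33600 nM
compound 3 `COc1cc(/C=N/Nc2nc(-c3ccc(C(F)(F)F)cc3)cs2)cc(Br)c1OC` 31200 nM

These three compounds were tested in a functional assay on HepG2 cells (Homo sapiens) for inhibition, read by MTT assay, with a stated time of 48 h; a higher number here means a weaker inhibitor, a lower number a stronger inhibitor. Compound 3 gives the lowest of the three numbers there, yet its gap to compound 2 lies within the usual scatter of repeated measurements, so the two cannot be told apart; only compound 1 stands beyond the scatter, with the higher number. Among the compounds with values here, no two of the measured compounds differ in a single place, so no step between them can be read directly.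

Compound 4 `COc1cc(/C=N/Nc2nc(-c3ccccc3)cs2)cc(Br)c1OC` differs from compound 3 by hydrogen in place of trifluoromethyl on an aromatic carbon. Without a measured step that isolates this change, the expectation rests on the spread of the three values alone. Compound 4 is expected to land close to compound 3, with the step of a 1.4-fold higher number from compound 3 to compound 4 (0.16 log units; within the scatter) estimated to be small and toward a somewhat higher number, probably within the scatter. For compound 4 the estimate in this assay is 45000 nM, with a range from 20000 nM to 100000 nM.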

Compound 4, half-maximal inhibitory concentration: 68300 nM
Compound 4: the middle estimate sits 1.5-fold (0.18 log units) below what was measured; low and high end bracket the measured number.
By their numbers in this assay, from the lowest: compounds 3, 2, 1 and 4 (each within the scatter of the next, the first and the last beyond it).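

In this assay, hydrogen in place of trifluoromethyl on an aromatic carbon gives a 2.2-fold higher number from compound 3 to compound 4 (0.34 log units; beyond the scatter) and shows that, at this place, the trifluoromethyl compound is the stronger inhibitor of the pair. Hydrogen in place of bromo on an aromatic carbon gives a 2.0-fold higher number from compound 2 to compound 4 (0.31 log units; beyond the scatter) for one bromo, but a 1.0-fold higher number from compound 1 to compound 4 (0.01 log units; within the scatter) for a bromo at a different place, so that second pair cannot be told apart. Across these pairs, then, the outcome of removing a group varies with the group and with where it sits.

From the compounds shown here alone, whether an amine, a carboxylic acid or a longer chain on this same aromatic carbon would give a lower or a higher number stays open. Nothing measured here explains why any of these steps has its size.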